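Triazole-linked nucleoside series: ethoxycarbonyl replaces phenyl

This account rests on a few compounds, and the source may have more. Where it says the series, first, only, none or still open, it means among the compounds named here.

Measured so far:
- compound 1, `CCS[C@@H]1[C@H](SCC)[C@@H](Cn2cc(-c3cccs3)nn2)O[C@H]1n1ccc(=O)[nH]c1=O`, in a functional assay on LAC cells (Homo sapiens) for cytotoxicity, read by MTT assay, with a stated time of 72 h (a lower number here means that less compound is needed, a higher number that more compound is needed for the effect), gives 86500 nM
- compound 2, `CCS[C@@H]1[C@H](SCC)[C@@H](Cn2cc(-c3ccccc3)nn2)O[C@H]1n1cc(C)c(=O)[nH]c1=O`, in this assay gives "not determined" (no result reported)

Going by the values given here, compound 1 stands as the only compound of the series with a number in this assay, and that number is a weak one. Compound 2 has no single number in this assay to stand on, so its position relative to compound 1 cannot be stated.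

Compound 3, `CCOC(=O)c1cn(C[C@H]2O[C@@H](n3cc(C)c(=O)[nH]c3=O)[C@H](SCC)[C@@H]2SCC)nn1`, is the next member. Against compound 2 it shows (ethoxycarbonyl in place of phenyl on an aromatic carbon), that is, ethoxycarbonyl in place of phenyl on an aromatic carbon. Among the compounds with values here, no measured pair covers a change of this kind, and compound 2 itself brings no value, so there is no step to lean on. The only anchor is the weak result of compound 1 in this assay. With nothing in the series pointing toward a gain, the expectation for compound 3 in this assay is a value in the same weak region as compound 1, with no direction beyond the scatter assumed. Compound 3 is thus estimated at 100000 nM, with a range from 30000 nM to 300000 nM.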

Compound 3, half-maximal effective concentration: >= 100000 nM
Compound 3: a limit, no number; the forecaster's own chance of this, stated with the estimate: 40%; the middle value lies on the limit itself.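

In this assay compound 3 gives >= 100000 nM, which is a limit of the assay and not a number. Compound 2 has no single number, so no step can be read between compound 2 and compound 3. The compounds shown leave open whether ethoxycarbonyl in place of phenyl changes the result in this assay at all.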